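Trifluoromethyl for methyl on a pair of inactive compounds

A few compounds are considered here, and "the series" means these few. Any claim that something is new, unique, unknown or untested is made for them only; others in the source may bear on it.

compound 1, `O=C(NN=C1CC(c2ccccc2)NC(c2ccccc2)C1)c1ccc(F)cc1`: > 400000 nM
compound 2, `Cc1ccc(C(=O)NN=C2CC(c3ccccc3)NC(c3ccccc3)C2)cc1`: > 400000 nM

In a functional assay on A549 cells (Homo sapiens) for cytotoxicity, read by MTT assay, with a stated time of 24 h (a higher number here means a weaker inhibitor, a lower number a stronger inhibitor), compound 1 gives > 400000 nM, which is a limit of the assay and not a number. Compound 2 gives > 400000 nM in this assay, likewise only a limit. The step that the two limits leave unreadable from compound 1 to compound 2 therefore cannot be sized, since both values sit at the limit of > 400000 nM in this assay, at which 2 of the 2 values shown sit. Compound 3, `O=C(NN=C1CC(c2ccccc2)NC(c2ccccc2)C1)c1ccc(C(F)(F)F)cc1`, differs from compound 2 by trifluoromethyl in place of methyl on an aromatic carbon. With no readable step to build on, compound 3 is expected to remain at the limit too, a step estimated as a step that the limit leaves unreadable from compound 2 to compound 3. The estimate for compound 3 is 500000 nM, expected to lie between 200000 nM and 2000000 nM.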

Compound 3, half-maximal inhibitory concentration: > 400000 nM
Compound 3 gave a limit, no number; the forecaster's own chance of this, stated with the estimate: 85%; the middle value is on the limit's open side.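

Among the compounds shown here, compound 3 also gives only a limit in this assay, > 400000 nM, so no step among compound 1, compound 2 and compound 3 can be read: the limit of > 400000 nM in this assay, at which 3 of the 3 values shown sit. On these data alone, whether any group at this place on the aromatic ring would give a measurable value stays open.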